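Trimming one methoxy from the benzyl group of compound 1

The source may report more compounds than this note shows. Statements on the series, on what has been measured and on what is new or still open speak of the compounds shown alone.

Among the measured compounds shown here, compound 1 `COc1ccc(CNc2nc3cc(N)cc(N)c3nc2-c2ccccc2)cc1OC` is the only member of the series with a measured number: in a functional assay on NCI-H522 cells (Homo sapiens) for inhibition, read by sulforhodamine B assay, with a stated time of 48 h (on this read-out higher numbers stand for weaker inhibition of growth and lower numbers for stronger inhibition of growth), compound 1 gives 6310 nM. Compound 2 `COc1cc(CNc2nc3cc(N)cc(N)c3nc2-c2ccccc2)cc(OC)c1OC` carries one methoxy more, and in this assay its value, < 50200 nM, is a limit of the assay and not a number. The step that the limit leaves unreadable from compound 1 to compound 2 is therefore not readable in size, and the limit of < 50200 nM in this assay, at which 1 of the 2 values shown sits, is all the evidence shown on a methoxy change in this series. Compound 3 `COc1ccc(CNc2nc3cc(N)cc(N)c3nc2-c2ccccc2)cc1` differs from compound 1 by hydrogen in place of methoxy on an aromatic carbon. For the measured compounds named here, no measured step reads on removing a methoxy, and the single step that touches a methoxy is unreadable, so no shift beyond the scatter is expected in either direction. For compound 3 the expected value is 6300 nM, with a range of 2500 nM to 16000 nM. The expected step of a 1.0-fold lower number from compound 1 to compound 3 (0.00 log units; within the scatter) stays within the usual scatter.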

Compound 3, concentration for total growth inhibition: 21900 nM
Compound 3: middle estimate off by 3.5-fold (0.54 log units), on the low side; measured number outside the range, above it.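

In this assay, among the compounds shown here, the change from 3,4-dimethoxyphenyl to 4-methoxyphenyl gives a 3.5-fold higher number from compound 1 to compound 3 (0.54 log units; beyond the scatter) and is the first readable step on a methoxy. It shows that this methoxy, ortho to a methoxy group, is not interchangeable with hydrogen: hydrogen in its place goes with weaker inhibition of growth. Compound 2 gives < 50200 nM as a limit and not a number, so the step to it cannot be read, and nothing shown gives a cause for the step to hydrogen.

Open, as far as these compounds go, is whether a hydroxyl, a fluorine or an amine at this position would hold up as the methoxy does, or whether only the methoxy serves. Also open, from the compounds shown here alone, is how a plain phenyl, with neither methoxy, or a longer ether such as ethoxy would read on the same scale.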